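A few compounds are considered here, and "the series" means these few. Any claim that something is new, unique, unknown or untested is made for them only; others in the source may bear on it.

In a functional assay on Huh-7 cells (Homo sapiens) for antiproliferative activity, read by CCK-8 assay, with a stated time of 72 h (a higher number here means a weaker inhibitor of growth, a lower number a stronger inhibitor of growth), compound 1, with the structure `CCCNS(=O)(=O)c1ccc(Nc2ncc3c(n2)N(C2CCCC2)[C@H](CC)C(=O)N3C)cc1`, gives 278 nM. Compound 2, with the structure `CC[C@@H]1C(=O)N(C)c2cnc(-n3ccc4cc(F)ccc43)nc2N1C1CCCC1`, gives 16000 nM in this assay, the higher of the two numbers reported, and its gap to compound 1 lies beyond the usual scatter. Compound 3, with the structure `CCC1C(=O)N(C)c2cnc(-n3ccc4cc(C(N)=O)ccc43)nc2N1c1ccn(C)n1`, is reported in this assay as "not active" (no number reported), with no number given. Compound 4, with the structure `CC[C@@H]1C(=O)N(C)c2cnc(-n3ccc4cc(C(N)=O)ccc43)nc2N1C1CCCC1`, has not yet been measured; it differs from compound 2 by carbamoyl in place of fluoro on an aromatic carbon. Compound 3 also carries a carbamoyl and is not active, though it differs from compound 4 in more than this one place. From compound 2 to compound 4 a step of a 1.6-fold higher number from compound 2 to compound 4 (0.19 log units; within the scatter) is therefore expected, toward a weaker inhibitor. Compound 4 is estimated at 25000 nM, between 6000 nM and 100000 nM.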

Compound 4, concentration for 50% growth inhibition: 3090 nM
Beside the measured number, compound 4's estimate is 8.1-fold (0.91 log units) above it; measured number outside the range, below it.
By their numbers in this assay, from the lowest: compound 1; then compound 4; then compound 2.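

In this assay, carbamoyl in place of fluoro on this aromatic carbon gives a 5.2-fold lower number from compound 2 to compound 4 (0.71 log units; beyond the scatter), a change beyond the usual scatter. The position is therefore sensitive to what sits on it, and a group with more heavy atoms, a hydrogen-bond donor and a hydrogen-bond acceptor is tolerated there, with stronger growth inhibition than fluoro gives. On these data alone, whether an amine, a carboxylic acid or a nitrile on the same carbon would lower the number further remains open. No measurement shown bears on the cause of this step.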